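Inverting the fluorinated centre of a saturated lysophosphatidate analogue

The source may report more compounds than this note shows. Statements on the series, on what has been measured and on what is new or still open speak of the compounds shown alone.

Compound 1, `CCCCCCCC/C=C/CCCCCCCC(=O)OC[C@@H](F)COP(=O)(O)O`: > 10000 nM in an in vitro functional assay on Sf9 cells for agonist activity at lysophosphatidic acid receptor 3 (Homo sapiens), read by calcium flux; a higher number here means that more compound is needed for the effect, a lower number that less compound is needed
Compound 2, `CCCCCCCCCCCCCCCC(=O)OC[C@@H](F)COP(=O)(O)O`: > 10000 nM in this assay

Compound 2 sits only at a limit of this assay, > 10000 nM, not at a number. Compound 1 also returns only a limit, > 10000 nM. Both values rest on (the limit of > 10000 nM in this assay, at which 2 of the 2 values shown sit). Compound 3, `CCCCCCCCCCCCCCCC(=O)OC[C@H](F)COP(=O)(O)O`, differs from compound 2 as follows: the two compounds have the same atoms and bonds and differ only in configuration as drawn: 1 of 1 stereo elements differ; a stereocentre at a saturated chain carbon is drawn R in compound 2 and S in compound 3. For the measured compounds named here, no measured step of this kind is available, so the size of the change is uncertain. Compound 3 is estimated at 3000 nM, between 300 nM and 30000 nM, which would mean an expected step of an at least 3.3-fold lower number from compound 2 to compound 3 (0.52 log units; beyond the scatter).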

Compound 3, half-maximal effective concentration: > 10000 nM
Compound 3 ended at the assay's limit (the forecaster's own chance of this, stated with the estimate: 50%); middle value at least 3.3-fold (0.52 log units) away from the limit.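

No step from compound 2 to compound 3 can be read, because both stop at a limit and not at a number: the limit of > 10000 nM in this assay, at which 3 of the 3 values shown sit.

The compounds shown leave open whether the R and S configurations at this stereocentre differ at all in this assay.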